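This account rests on a few compounds, and the source may have more. Where it says the series, first, only, none or still open, it means among the compounds named here.

Working notes on the series. Compound 1 `COc1cc(OC)c(OC)cc1/C=C/C(=O)c1ccc(Cl)cc1` and compound 2 `COc1cc(OC)c(C(=O)/C=C/c2cc(OC)c(OC)cc2OC)c(OC)c1` have been measured so far. In a functional assay on MCF7 cells (Homo sapiens) for inhibition, read by MTT assay, with a stated time of 72 h (a higher number here means a weaker inhibitor, a lower number a stronger inhibitor), compound 1 gives 29500 nM and compound 2 gives 51400 nM. Of the two numbers, compound 1 has the lower one, but the gap to compound 2 lies within the scatter, so the two compounds are not separated on these data. Among the measured compounds shown here, no step between measured compounds that differ in one place is available.

Compound 3 `COc1cc(OC)c(OC)cc1/C=C/C(=O)c1ccc(Br)cc1` is not yet measured. It differs from compound 1 by one change (bromo in place of chloro on an aromatic carbon); with only one atom exchanged and no change in ring, donor or acceptor count, the expected step from compound 1 to compound 3 in this assay is small, a 1.2-fold lower number from compound 1 to compound 3 (0.07 log units; within the scatter), and not clearly beyond the scatter in either direction. Compound 3 is therefore expected to give about 25000 nM in this assay, with a range from 10000 nM to 60000 nM.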

Compound 3, half-maximal inhibitory concentration: 18300 nM
The estimate for compound 3 lay 1.4-fold (0.14 log units) above the measured number, and the stated range covers the measured number.
By their numbers in this assay, from the lowest: compounds 3, 1 and 2 (each within the scatter of the next, the first and the last beyond it).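

Among the compounds shown here, this is the first step that changes only one place: in this assay, bromo in place of chloro on an aromatic carbon gives a 1.6-fold lower number from compound 1 to compound 3 (0.21 log units; within the scatter). The two halogens are therefore not separated at this position, para to a large group, and this one exchange of a single heavy atom, with no change in hydrogen-bond donors or acceptors, does not move the number beyond the scatter. No measurement is available that bears on the reason for this result.

The compounds shown carry only chloro or bromo at this position in the one-place comparison, so the effect of a non-halogen group there, such as an amine or a carboxylic acid, remains open. From the compounds shown here alone, the contribution of the methoxy groups on the shared core also remains open.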